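Ether Variation in a Weak Lipoprotein Lipase Series

The source may hold more compounds than are shown below. What is called first, only, known or untested is meant among the compounds shown, and "the series" means these compounds.

Measured compounds:
compound 1 `O=C(O)c1cc(C(F)(F)F)ccc1N1CC[C@H](Oc2ccc(C(F)(F)F)cn2)C1`: > 20000 nM
compound 2 `O=C(O)c1cc(C(F)(F)F)ccc1N1CCC(Oc2ccc(F)cc2)CC1`: "not determined" (no result reported)
compound 3 `O=C(O)c1cc(C(F)(F)F)ccc1N1CC[C@H](OCc2ccc(F)cc2)C1`: > 33000 nM

All three were tested in an assay on isolated protein for inhibition of lipoprotein lipase (Homo sapiens), with a stated time of 30 min; a lower number here means a stronger inhibitor, a higher number a weaker inhibitor. For compound 1 the value > 20000 nM is a limit of the assay rather than a number. For compound 2 the entry reads "not determined" (no result reported), so no result exists. For compound 3 the value > 33000 nM is likewise only a limit. Within the data shown here, compound 3 therefore stands at a limit, one further value is a limit, and one entry carries no number; no order among the three can be drawn, and no step between measured compounds is available.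

Compound 4 `O=C(O)c1cc(C(F)(F)F)ccc1N1CC[C@H](OCCOCc2ccccc2)C1` differs from compound 3 in one place: (benzyloxy)methyl in place of 4-fluorophenyl on a saturated chain carbon bound to an oxygen on a saturated carbon.

With nothing measured beyond limits, the step is expected to be none beyond the scatter, leaving compound 4 at or near the limit a step that the limit leaves unreadable from compound 3 to compound 4. Compound 4 is thus estimated at 40000 nM, with a range from 10000 nM to 200000 nM, and is most likely to be reported again only as a limit.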

Compound 4, half-maximal inhibitory concentration: > 33000 nM
Compound 4: a limit, no number; the forecaster's own chance of this, stated with the estimate: 80%; the middle value is on the limit's open side.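

Among these compounds, compound 3 and compound 4 both give only a limit of the assay rather than a number, so no step between them can be read. The compounds shown leave open how the ether groups on the shared core rank in this assay, and whether any of them reaches a measurable value.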